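Octyl versus butyl amine chains on two quinone cores

A few compounds are considered here, and "the series" means these few. Any claim that something is new, unique, unknown or untested is made for them only; others in the source may bear on it.

In a functional assay on NCI-H460 cells (Homo sapiens) for cytotoxicity, read by MTT assay, with a stated time of 72 h (a lower number here means a stronger inhibitor, a higher number a weaker inhibitor), compound 3 `CCCCNC1=CC(=O)C=C(C[C@]2(C)[C@@H](C)CC[C@]3(C)C(C)=CCC[C@@H]23)C1=O` gives 16000 nM, and compound 1 `CCCCCCCCNC1=CC(=O)C=C(C[C@]2(C)[C@@H](C)CC[C@]3(C)C(C)=CCC[C@@H]23)C1=O` gives 38000 nM. The change between them is butyl in place of hydrogen on a saturated chain carbon, four bonds along the chain from an amine nitrogen, and it produced a 2.4-fold higher number from compound 3 to compound 1 (0.38 log units; beyond the scatter). Compound 2 `CCCCNC1=CC(=O)C(C(C)(C)C)=CC1=O` carries a different core; the difference between the two cores is not broken down here. In this assay compound 2 gives 36000 nM, which lies within the scatter of the value of compound 1 and beyond the scatter from the value of compound 3. Compound 4 `CCCCCCCCNC1=CC(=O)C(C(C)(C)C)=CC1=O` has not yet been measured in this assay. It is made from compound 2 by butyl in place of hydrogen on a saturated chain carbon, four bonds along the chain from an amine nitrogen, the same change as from compound 3 to compound 1, at the same place on the chain. Going by the values given here, the expectation rests on a 2.4-fold higher number from compound 3 to compound 1 (0.38 log units; beyond the scatter), the only earlier instance of this change. A weaker inhibitor is expected, with a 2.2-fold higher number from compound 2 to compound 4 (0.35 log units; beyond the scatter). The step occurs only once among the measured compounds, and on a different core, so the range is kept wide. Compound 4 is estimated at 80000 nM in this assay, expected to fall between 36000 nM and 170000 nM.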

Compound 4, half-maximal inhibitory concentration: 70000 nM
For compound 4 the middle estimate is 1.1-fold (0.06 log units) above the measured one; low and high end bracket the measured number.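

In this assay, butyl in place of hydrogen, four bonds along the chain from the amine nitrogen, gives a 1.9-fold higher number from compound 2 to compound 4 (0.29 log units; within the scatter), and the two instances of this change agree across the two cores: the same change on two cores in this assay, a 2.4-fold higher number (0.38 log units; beyond the scatter) from compound 3 to compound 1 and a 1.9-fold higher number (0.29 log units; within the scatter) from compound 2 to compound 4, 1.2-fold (0.09 log units) apart, within the scatter of two such steps Read alone, the new step lies within the scatter and does not establish a difference between compound 2 and compound 4; the support for carrying the change over comes only from its agreement with the step on the other core. Two pairs on two cores show no more than that agreement, and they do not show that the change would behave the same way on any further core or at any other place on the molecule.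

Still open, on these data alone, is how the numbers run on either core with a chain longer than octyl, or with a chain ending in a carboxylic acid or an amine. As far as these compounds go, the two cores differ in more than one place, and how much each part of that difference contributes also remains open.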